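The source may report more compounds than this note shows. Statements on the series, on what has been measured and on what is new or still open speak of the compounds shown alone.

In a physicochemical assay for solubility, read by spectrophotometry, using the shake flask method, with a stated time of 48 h, at pH 6.5 (a lower number here means a less soluble compound, a higher number a more soluble compound), compound 1 `OCCOc1ccc2nc(-c3cn(-c4ccc(O)cc4)nn3)ccc2c1` gives 2.6 ug/mL and compound 2 `NCCOc1ccc2nc(-c3cn(-c4ccc(O)cc4)nn3)ccc2c1` gives 3.7 ug/mL. These two numbers lie within the scatter of each other, so compound 2 stands level with compound 1. Compound 3 `O=C(O)COc1ccc2nc(-c3cn(-c4ccc(O)cc4)nn3)ccc2c1` has not been measured yet. Its difference from compound 2 is carboxy in place of aminomethyl on a saturated chain carbon bound to an oxygen on an aromatic ring, in words carboxy in place of aminomethyl on a saturated chain carbon bound to an oxygen on an aromatic ring. For the measured compounds named here, only one measured step bears on this change: a 1.4-fold higher number from compound 1 to compound 2 (0.15 log units; within the scatter), with amino in place of hydroxy, stayed within the scatter. Going by the values given here, no measured compound carries carboxy, so that step is a weak guide and the direction remains uncertain. A moderate rise in this assay is nevertheless expected, an estimated 2.2-fold higher number from compound 2 to compound 3 (0.33 log units; beyond the scatter). For compound 3 the estimated value is 8 ug/mL, with an expected range from 2 ug/mL to 40 ug/mL.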

Compound 3, solubility: 365 ug/mL
Compound 3: middle estimate off by 46-fold (1.66 log units), on the low side; measured number above the stated range.
By their numbers in this assay, from the lowest: compounds 1 and 2 (each within the scatter of the next); then compound 3.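

In this assay, the group at the end of this chain can change the read-out greatly: carboxy in place of aminomethyl gives (a 99-fold higher number from compound 2 to compound 3 (1.99 log units; beyond the scatter)), and carboxy in place of hydroxymethyl gives (a 140-fold higher number from compound 1 to compound 3 (2.15 log units; beyond the scatter)). The earlier swap of amino for hydroxy stayed within the scatter (a 1.4-fold higher number from compound 1 to compound 2 (0.15 log units; within the scatter)), so that pair gave no sign of how far a change at this position could reach. No measurement shown here accounts for the size of the carboxy result.

The compounds shown leave open whether the carboxy group must stay intact, which a methyl ester or a primary amide at the same place would help to test. They also leave open how a longer chain carrying the same carboxy group would read.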